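Swapping the aryl group on a nitroimidazole-oxadiazole series

The compounds below may be only part of what the source reports. "The series", "measured", "known", "first", "only" and "open" are said of these compounds alone.

Of the compounds shown here, three sharing one core have been tested in a functional assay on SGC-7901 cells (Homo sapiens) for cytotoxicity, read by MTT assay, with a stated time of 48 h; a lower number here means a stronger inhibitor, a higher number a weaker inhibitor. Compound 1 `Cc1ccccc1-c1nnc(SCCn2c([N+](=O)[O-])cnc2C)o1` gives 32300 nM. Compound 2 `Cc1ncc([N+](=O)[O-])n1CCSc1nnc(-c2ccc(N)cc2)o1` gives 31700 nM, and compound 3 `Cc1cccc(-c2nnc(SCCn3c([N+](=O)[O-])cnc3C)o2)c1O` gives 35900 nM. Compound 1 thus sits second highest of the three numbers, but all three lie within the scatter of one another, so none can be called stronger or weaker than the rest.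

Compound 4 `Cc1ncc([N+](=O)[O-])n1CCSc1nnc(-c2ccncc2)o1` has not yet been measured. It differs from compound 1 in one place: pyridin-4-yl in place of 2-methylphenyl on an aromatic carbon. The change in this assay is a swap of the aryl group, and every measured step here is of that kind. The step of a 1.0-fold lower number from compound 1 to compound 2 (0.01 log units; within the scatter) and the step of a 1.1-fold higher number from compound 1 to compound 3 (0.05 log units; within the scatter) both stayed within the scatter, as did the step of a 1.1-fold higher number from compound 2 to compound 3 (0.05 log units; within the scatter). For the measured compounds named here, three different aryl groups, with or without a hydroxyl or an amino group, therefore gave the same number within error, and nothing among the measured compounds suggests that a pyridin-4-yl would behave differently.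

The expectation for compound 4 is accordingly a step of a 1.0-fold lower number from compound 1 to compound 4 (0.00 log units; within the scatter), that is, no change beyond the scatter. Compound 4 is estimated at 32000 nM, with a range from 16000 nM to 64000 nM.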

Compound 4, half-maximal inhibitory concentration: 15900 nM
The estimate for compound 4 lay 2.0-fold (0.30 log units) above the measured number; the measured number lies below the stated range.
By their numbers in this assay, from the lowest: compounds 4, 2, 1 and 3 (each within the scatter of the next, the first and the last beyond it).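

For the compounds shown here, the aromatic carbon of the five-membered ring in the shared core is not wholly indifferent to its aryl group in this assay: pyridin-4-yl gives a 2.0-fold lower number from compound 1 to compound 4 (0.31 log units; beyond the scatter) and a 2.3-fold lower number from compound 3 to compound 4 (0.35 log units; beyond the scatter), the first steps in this set to pass beyond the scatter, though both are modest. The picture is not uniform, since the step to the same group from 4-aminophenyl, a 2.0-fold lower number from compound 2 to compound 4 (0.30 log units; within the scatter), stays within the scatter, so the lower number for compound 4 holds against compound 1 and compound 3 but not against compound 2. Nothing available explains why the pyridin-4-yl change shifts the number in these two steps.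

On these data alone, it remains open whether the ring nitrogen of pyridin-4-yl is what counts, or simply the absence of the methyl group carried by compound 1 and compound 3; a plain phenyl on the same carbon would separate those two readings. A pyridin-3-yl would likewise show whether the place of the nitrogen within the six-membered ring matters for this modest shift.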